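The source may hold more compounds than are shown below. What is called first, only, known or untested is meant among the compounds shown, and "the series" means these compounds.

In an ADME assay on microsomes from liver (Mus musculus) for metabolic stability, read by HPLC, using NADPH, with a stated time of 10 min (a higher number here means that the compound lasts longer, a lower number that the compound disappears faster), compound 1 (`COc1ccc(-c2nn3c(-c4cccs4)nnc3s2)cc1OC`) gives 0.0167 h, and compound 2 (`c1csc(-c2nnc3sc(-c4cnccn4)nn23)c1`) gives 0.0167 h. Compound 2 therefore stands level with compound 1, with no change at the digits reported and nothing beyond the usual scatter. Compound 3 (`Cc1cc(-c2nn3c(-c4cccs4)nnc3s2)n[nH]1`) keeps the rest of compound 2 and exchanges one group: 5-methyl-1H-pyrazol-3-yl comes in place of pyrazin-2-yl on an aromatic carbon (5-methyl-1H-pyrazol-3-yl in place of pyrazin-2-yl on an aromatic carbon). That carbon belongs to a five-membered aromatic ring with 2 nitrogen and 1 sulfur, part of a fused or bridged system of two rings. Within the data shown here, no measured pair of compounds differing in one place is available to gauge such an exchange. Among the measured compounds shown here, the only guide is that compound 1 at 0.0167 h and compound 2 at 0.0167 h are level while carrying different groups at this place, although two compounds establish no pattern. The expected change is slight and upward, an estimated 1.5-fold higher number from compound 2 to compound 3 (0.18 log units; within the scatter), which would stay within the scatter. For compound 3 the estimated half-life is 0.025 h, with an expected range from 0.0125 h to 0.1 h.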

Compound 3, half-life in the liver assay: 0.0333 h
Estimate against measurement, compound 3: 1.3-fold (0.12 log units) below; low and high end bracket the measured number.
By their numbers in the liver assay, from the lowest: compounds 1, 2 and 3 (each within the scatter of the next).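

Among these compounds, this exchange gives the first measured step at this position, an aromatic carbon next to the ring nitrogen and next to the ring sulfur, and in the liver assay it reads as (a 2.0-fold higher number from compound 2 to compound 3 (0.30 log units; within the scatter)) when 5-methyl-1H-pyrazol-3-yl takes the place of pyrazin-2-yl, with compound 2 at 0.0167 h and compound 3 at 0.0333 h. In a physicochemical assay for solubility, measured as kinetic solubility (a higher number here means a more soluble compound, a lower number a less soluble compound), the same exchange reads as (a 1.9-fold higher number from compound 2 to compound 3 (0.29 log units; within the scatter)), with compound 2 at 30000 nM and compound 3 at 58000 nM, so the position has now taken a five-membered ring carrying a hydrogen-bond donor in place of a six-membered ring with no step beyond the scatter in either assay. No accompanying data bear on what lies behind these two steps.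

The compounds shown leave open whether a different kind of group on this carbon, such as an amine, a carboxylic acid or a longer chain, would produce a step beyond the scatter in the liver assay or in the physicochemical assay. Among the compounds shown here, they also leave open whether the same exchange would read alike on a compound that differs elsewhere, as this single pair is the only measured step at hand.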